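The source may report more compounds than this note shows. Statements on the series, on what has been measured and on what is new or still open speak of the compounds shown alone.

Measured compounds, each reported only as a limit:
- Compound 1 `Cc1cc(-c2ccccc2)nnc1NCCN`: > 30 mg/kg
- Compound 2 `CNCCNc1nnc(-c2ccccc2)cc1C`: >= 30 mg/kg

Both compounds were tested in a functional assay on the whole organism for positive allosteric modulation, with Mus musculus as the target; a lower number here means that less compound is needed, a higher number that more compound is needed for the effect. In this assay, compound 2 gives >= 30 mg/kg, which is a limit and not a number. Compound 1 also gives only a limit, > 30 mg/kg. For the measured compounds named here, the one measured step, methyl in place of hydrogen on an amine nitrogen, is a step that the two limits leave unreadable from compound 1 to compound 2. It therefore offers no size or direction to carry forward.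

The next compound is compound 3 `CCN(CC)CCNc1nnc(-c2ccccc2)cc1C`. It has diethylamino in place of methylamino on a saturated chain carbon, two bonds along the chain from a nitrogen on an aromatic ring. The measured step from compound 1 also changes substitution on an amine nitrogen, but it shows no size, so no step beyond the scatter can be predicted in this assay. The estimate stays anchored to the limit of compound 2, and a limit may well be reported again. The expected change is a number no higher from compound 2 to compound 3 (the limit leaves the size open). For compound 3, the estimated dose is 30 mg/kg, with an expected range from 12 mg/kg to 60 mg/kg.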

Compound 3, dose for half-maximal effect: > 30 mg/kg
Compound 3 ended at the assay's limit; the forecaster's own chance of this, stated with the estimate: 65%; the middle value sits exactly at the limit.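

In this assay compound 3 gives > 30 mg/kg, which is a limit and not a number. Compound 1 and compound 2 are also reported only as limits, so the steps among compound 1, compound 2 and compound 3 cannot be read. The compounds shown leave open what dose any of them needs, and whether the amine substitution changes it at all.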